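Removing the indole from a piperidine oxazolidinone

The compounds below may be only part of what the source reports. "The series", "measured", "known", "first", "only" and "open" are said of these compounds alone.

Measured compounds:
compound 1: `COc1ccc2nccc(C3CN(C4CCN(Cc5cc6ccccc6[nH]5)CC4)C(=O)O3)c2c1` — 25.1 nM
compound 2: `COc1ccc2nccc(C3CN(C4CCN(Cc5cc6ccccc6[nH]5)C4)C(=O)O3)c2c1` — < 50200 nM

Going by the values given here, in an in vitro functional assay on RBL cells for antagonist activity at C-C chemokine receptor type 8 (Homo sapiens), read by FLIPR and calcium flux (on this read-out lower numbers stand for stronger inhibition and higher numbers for weaker inhibition), compound 1 gives 25.1 nM, the only actual number among the two values shown. For compound 2 this assay reports only a limit, < 50200 nM. Among the compounds with values here, the other entry, (the limit of < 50200 nM in this assay, at which 1 of the 2 values shown sits), gives no measurable step between the two.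

Compound 3, `COc1ccc2nccc(C3CN(C4CCN(C)CC4)C(=O)O3)c2c1`, differs from compound 1 by hydrogen in place of 1H-indol-2-yl on a saturated chain carbon bound to an amine nitrogen in a ring. Within the data shown here, no measured step covers this change, so the size of the step of a 240-fold higher number from compound 1 to compound 3 (2.38 log units; beyond the scatter) is estimated, and it is expected to be a loss far beyond the scatter. Compound 3 is expected to give 6000 nM, within 600 nM to 50000 nM.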

Compound 3, half-maximal inhibitory concentration: < 50200 nM
Compound 3 was reported as a limit; the forecaster's own chance of this, stated with the estimate: 40%; the middle value is on the limit's open side.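

Compound 3 is reported only as a limit, so no step can be read from compound 1 to compound 3: the limit of < 50200 nM in this assay, at which 2 of the 3 values shown sit. The compounds shown leave open how large the change from (1H-indol-2-yl)methyl to methyl actually is.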